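This account rests on a few compounds, and the source may have more. Where it says the series, first, only, none or still open, it means among the compounds named here.

In an assay on isolated protein for inhibition of aldehyde dehydrogenase 1A1 (Homo sapiens), read by spectrophotometry, tested at 10 uM (on this read-out lower numbers stand for less inhibition and higher numbers for more inhibition at the one concentration tested (going by the name of the read-out)), compound 1 `Cc1cccc(Cn2c(CN3CCN(C(=O)c4cccs4)CC3)nc3ccccc32)c1` gives 60.8%, the highest of the three numbers shown. Compound 2 `O=C(C1CC1)N1CCN(Cc2nc3ccccc3n2Cc2cccc(F)c2)CC1` gives 27.2% and compound 3 `O=C(C1CC1)N1CCN(Cc2nc3ccccc3n2Cc2ccccc2)CC1` gives 23.9%; both carry a cyclopropylcarbonyl on the piperazine where compound 1 carries a (thiophen-2-yl)carbonyl, and both also differ from compound 1 on the benzyl group. Within the data shown here, the only step between single-change neighbours, a number 3.3 percentage points lower from compound 2 to compound 3 (within the scatter), concerns the benzyl group and does not bear on the change at the carbonyl carbon.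

Compound 4 `Cc1cccc(Cn2c(CN3CCN(C(=O)C(C)C)CC3)nc3ccccc32)c1` differs from compound 1 by isopropyl in place of thiophen-2-yl on a carbonyl carbon. Among the measured compounds shown here, no measured pair isolates this change. Going by these compounds, the two compounds bearing a small aliphatic group on the carbonyl carbon, compound 2 and compound 3, sit well below compound 1, but that gap mixes two differences, so its size for the carbonyl change alone is unknown. Compound 4 is therefore expected to fall below compound 1 by a number 25.8 percentage points lower from compound 1 to compound 4 (beyond the scatter), with wide uncertainty. Compound 4 is estimated at 35%, between 15% and 55%.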

Compound 4, a percentage reported as inhibition, at one concentration (the size of the read-out at that concentration, not a potency): 87.2%
Beside the measured number, compound 4's estimate is 52.2 percentage points below it; measured number above the stated range.
By their numbers in this assay, from the lowest: compounds 3 and 2 (each within the scatter of the next); then compound 1; then compound 4.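

Among these compounds, with only the group on the carbonyl carbon changed, this assay shows a number 26.4 percentage points higher from compound 1 to compound 4 (beyond the scatter), the first reading at this place that is free of any change on the benzyl group. The thiophen-2-yl ring is therefore not required for a high number in this series, as isopropyl, with no ring and no hydrogen-bond acceptor, gives more inhibition at the one concentration tested. Nothing shown accounts for the direction of this step.

The compounds shown leave open how a tert-butyl group, a longer chain such as n-butyl, or a dimethylamino group on the carbonyl carbon would read. Going by these compounds, it also remains open whether the same step would appear with a different benzyl group, and how it would translate into potency, since each number comes from a single concentration.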